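The source may hold more compounds than are shown below. What is called first, only, known or untested is meant among the compounds shown, and "the series" means these compounds.

Series notes. The three measured compounds share one core and differ only in the group on the carbonyl carbon attached to the ring nitrogen. Compound 1 `CC(C)(C)OC(=O)N1CCC(CN(Cc2ccc(Cl)cc2)Cc2ccc([N+](=O)[O-])s2)C1` gives 1800 nM in a functional assay on HEK293 cells for agonist activity at nuclear receptor subfamily 1 group D member 1 (Homo sapiens), read by a luciferase reporter, with a stated time of 24 h; on this read-out higher numbers stand for an effect only at larger amounts of compound and lower numbers for an effect already at smaller amounts. Compound 2 `CC(=O)N1CCC(CN(Cc2ccc(Cl)cc2)Cc2ccc([N+](=O)[O-])s2)C1` gives 1600 nM in this assay. Compound 3 `C=CCOC(=O)N1CCC(CN(Cc2ccc(Cl)cc2)Cc2ccc([N+](=O)[O-])s2)C1` gives 670 nM in this assay. Of the three numbers, compound 3 holds the lowest: the step of a 2.7-fold lower number from compound 1 to compound 3 (0.43 log units; beyond the scatter) and the step of a 2.4-fold lower number from compound 2 to compound 3 (0.38 log units; beyond the scatter) are both modest but beyond the scatter, whereas the step of a 1.1-fold lower number from compound 1 to compound 2 (0.05 log units; within the scatter) stays within it.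

Compound 4 `CCCCNC(=O)N1CCC(CN(Cc2ccc(Cl)cc2)Cc2ccc([N+](=O)[O-])s2)C1` is the next step: butylamino in place of allyloxy on a carbonyl carbon. Going by the values given here, no measured step puts a nitrogen on that carbonyl carbon, so none bears on it directly; the nearest reference points are the other changes at the same place, which moved the number only modestly, as in a 2.7-fold lower number from compound 1 to compound 3 (0.43 log units; beyond the scatter) and a 2.4-fold lower number from compound 2 to compound 3 (0.38 log units; beyond the scatter). A step of similar size is therefore expected in this assay, with no firm direction, and a small rise back toward the numbers of compound 1 and compound 2 is the more likely outcome. For compound 4 the expected step is a 1.5-fold higher number from compound 3 to compound 4 (0.17 log units; within the scatter). Compound 4 is estimated at 1000 nM, in a range from 400 nM to 2800 nM.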

Compound 4, half-maximal effective concentration: 670 nM
Beside the measured number, compound 4's estimate is 1.5-fold (0.17 log units) above it; the range from low to high includes it.
By their numbers in this assay, from the lowest: compounds 3 and 4 (each within the scatter of the next); then compounds 2 and 1 (each within the scatter of the next).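

In this assay, the first nitrogen on this carbonyl carbon gives no change at the digits printed from compound 3 to compound 4 (within the scatter): butylamino, with 1 hydrogen-bond donor where allyloxy has 0 and without the double bond of allyloxy, matches allyloxy at this place. Both groups stand apart from the other two, as shown by a 2.4-fold lower number from compound 2 to compound 4 (0.38 log units; beyond the scatter) and a 2.7-fold lower number from compound 1 to compound 4 (0.43 log units; beyond the scatter), so the lower numbers in this set are reached with either oxygen or nitrogen on the carbonyl carbon; compound 1 goes against any reading based on that atom alone, since its tert-butoxy also places oxygen there and its number remains in the higher pair. The data at hand offer no explanation for why butylamino and allyloxy match or why tert-butoxy does not.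

Still open, on these data alone, is how far the chain can vary on this carbonyl carbon, for example whether the shorter propylamino, the longer hexylamino or the ring-bearing benzylamino would stay with compound 3 and compound 4. Also open, as far as these compounds go, is whether the amide hydrogen matters, a question that dimethylamino at the same place would address.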